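Cyclohexylmethyl on the Piperazine Nitrogen of a Sigma-1 Ligand

The source may hold more compounds than are shown below. What is called first, only, known or untested is meant among the compounds shown, and "the series" means these compounds.

Of the compounds shown here, three sharing one core have been measured in an assay on membranes from brain for displacement of a labelled ligand from Sigma non-opioid intracellular receptor 1 (Cavia porcellus), read by scintillation counting, with a stated time of 120 min; on this read-out lower numbers stand for stronger inhibition and higher numbers for weaker inhibition. Compound 1 `Cc1cccc2sc(NC(=O)CCN3CCN(C(C)C)CC3)nc12` gives 1300 nM. Compound 2 `Cc1cccc2sc(NC(=O)CCN3CCN(C(C)(C)C)CC3)nc12` gives 147 nM. Compound 3 `CCCCN1CCN(CCC(=O)Nc2nc3c(C)cccc3s2)CC1` gives 204 nM. Compound 2 thus has the lowest number of the three, though its gap to compound 3 is within the usual scatter, whereas the step of an 8.8-fold lower number from compound 1 to compound 2 (0.95 log units; beyond the scatter) is well beyond it.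

Compound 4 `Cc1cccc2sc(NC(=O)CCN3CCN(CC4CCCCC4)CC3)nc12` is not yet measured. It differs from compound 2 in one place: cyclohexylmethyl in place of tert-butyl on an amine nitrogen in a ring. Among the compounds with values here, two measured steps bear on this change. The step of an 8.8-fold lower number from compound 1 to compound 2 (0.95 log units; beyond the scatter) and the step of a 6.4-fold lower number from compound 1 to compound 3 (0.80 log units; beyond the scatter) both show that a larger group on that ring nitrogen went with a lower number, while the step of a 1.4-fold higher number from compound 2 to compound 3 (0.14 log units; within the scatter) shows that two different larger groups came out alike. A further enlargement is therefore expected to give at most a small step, a 1.6-fold lower number from compound 2 to compound 4 (0.21 log units; within the scatter), and possibly none beyond the scatter.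

Compound 4 is estimated at 90 nM in this assay, with a likely range from 30 nM to 300 nM.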

Compound 4, inhibition constant: 35 nM
Beside the measured number, compound 4's estimate is 2.6-fold (0.41 log units) above it; low and high end bracket the measured number.
By their numbers in this assay, from the lowest: compound 4; then compounds 2 and 3 (each within the scatter of the next); then compound 1.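

In this assay, within the data shown here, the earlier compounds left it unclear whether anything larger on this ring nitrogen could still lower the number, and cyclohexylmethyl shows that it can, even against tert-butyl (a 4.2-fold lower number from compound 2 to compound 4 (0.62 log units; beyond the scatter)) and butyl (a 5.8-fold lower number from compound 3 to compound 4 (0.77 log units; beyond the scatter)). Against isopropyl the change is large (a 37-fold lower number from compound 1 to compound 4 (1.57 log units; beyond the scatter)), so this one position, with the rest of the molecule held the same, spans a wide range of numbers and compound 4 has the lowest of the four. No accompanying measurement explains why this group gives a lower number than the others.

The compounds shown leave open whether the ring must be non-aromatic, which a benzyl group on the same nitrogen would test. They also leave open how much the link between the ring and the nitrogen matters, which cyclohexyl attached directly or a cyclohexylethyl chain would test.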